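Pyridin-2-yl in place of thiadiazolyl on the sulfur

The compounds below may be only part of what the source reports. "The series", "measured", "known", "first", "only" and "open" are said of these compounds alone.

Of the compounds shown here, two sharing one core have been measured in a physicochemical assay, at pH 7.4; on this read-out higher numbers stand for a longer-lived compound and lower numbers for a shorter-lived compound. Compound 1 `CO[C@H]1C(=O)N2C(C(=O)C(C)(C)C)=C(CSc3nc(=O)c(=O)[nH]n3C)CS(=O)(=O)C12` gives 16 h in this assay. Compound 2 `CO[C@H]1C(=O)N2C(C(=O)C(C)(C)C)=C(C)[C@@H](Sc3nnc(C)s3)S(=O)(=O)C12` gives 27 h in this assay, the higher of the two numbers, yet its gap to compound 1 lies within the usual scatter, so the two show no real difference.

Compound 3 `CO[C@H]1C(=O)N2C(C(=O)C(C)(C)C)=C(C)[C@@H](Sc3ccccn3)S(=O)(=O)C12` has not been measured. It differs from compound 2 in one place: pyridin-2-yl in place of 5-methyl-1,3,4-thiadiazol-2-yl on a sulfur. Everything else in the structure, including the sulfur that carries the ring and the rest of the shared core, stays the same.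

Within the data shown here, no measured pair shows what this exchange does to the half-life. Among the measured compounds shown here, the only two numbers available stand within scatter of each other, so nothing here points to a change in either direction. The step from compound 2 to compound 3 is therefore expected to be small, no change at the digits printed from compound 2 to compound 3 (within the scatter), with no clear direction beyond the scatter. Compound 3 is estimated to give 27 h in this assay, within a range from 11 h to 65 h.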

Compound 3, half-life: 24 h
The estimate for compound 3 lay 1.1-fold (0.05 log units) above the measured number; the measured number falls inside the stated range.
By their numbers in this assay, from the lowest: compounds 1, 3 and 2 (each within the scatter of the next).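

On the sulfur whose other neighbour is a saturated ring carbon, putting pyridin-2-yl in place of 5-methyl-1,3,4-thiadiazol-2-yl gives, in this assay, a 1.1-fold lower number from compound 2 to compound 3 (0.05 log units; within the scatter) and so no real difference between the two compounds. Among these compounds, this is the first comparison at this position in which only one place differs, and it shows that, for this pair, a six-membered aromatic ring with 1 hetero atom and a five-membered aromatic ring with 3 hetero atoms cannot be told apart on this read-out. No separate measurement is available to explain this result.

On these data alone, whether an aromatic ring on this sulfur matters at all remains open, as does what a plain ethyl chain there, or a carboxylic acid or an amine attached to the pyridin-2-yl ring, would do in this assay. Compound 1 differs from compound 2 and compound 3 in more than one place, so it cannot show whether this exchange would give a similar result with the sulfur-bearing group placed as it is in compound 1.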